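Compound 3 to compound 4: cyclohexyl at the sulfur chain

The compounds below may be only part of what the source reports. "The series", "measured", "known", "first", "only" and "open" are said of these compounds alone.

Measured in a toxicity assay on GES1 cells (Homo sapiens) for inhibition, read by MTT assay, with a stated time of 72 h; a higher number here means a weaker inhibitor, a lower number a stronger inhibitor:
- compound 1 `Cc1cc(N2CC[C@@H](C)[C@@H](N(C)c3ncnc4[nH]ccc34)C2)n2nc(SCc3ccccc3)nc2n1`: 67200 nM
- compound 2 `Cc1cc(N2CC[C@@H](C)[C@@H](N(C)c3ncnc4[nH]ccc34)C2)n2nc(SCc3ccc(Cl)cc3)nc2n1`: > 100000 nM (a limit)
- compound 3 `Cc1cc(N2CC[C@@H](C)[C@@H](N(C)c3ncnc4[nH]ccc34)C2)n2nc(SCc3csc4ccc(Cl)cc34)nc2n1`: > 100000 nM (a limit)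

Compound 3 gives no number, only a limit: it sits at the limit of > 100000 nM in this assay, at which 2 of the 3 values shown sit.

The next structure is compound 4 `Cc1cc(N2CC[C@@H](C)[C@@H](N(C)c3ncnc4[nH]ccc34)C2)n2nc(SCC3CCCCC3)nc2n1`, and the change is cyclohexyl in place of 5-chloro-1-benzothiophen-3-yl on a saturated chain carbon bound to a sulfur. In words, it is cyclohexyl in place of 5-chloro-1-benzothiophen-3-yl on a saturated chain carbon bound to a sulfur.

Three measured steps change the same side of the molecule. These are an at least 1.4-fold higher number from compound 1 to compound 2 (0.17 log units; that floor lies within the scatter), an at least 1.4-fold higher number from compound 1 to compound 3 (0.17 log units; that floor lies within the scatter) and a step that the two limits leave unreadable from compound 2 to compound 3. None shows a change beyond the scatter, so no step beyond the scatter is expected in this assay. Within the data shown here, the only numeric anchor is compound 1 at 67200 nM, so the expectation stays close to that value. The expectation also stays close to the limit seen for compound 3. The expected step is an at least 1.2-fold lower number from compound 3 to compound 4 (0.09 log units; that floor lies within the scatter). Another reported limit would not be surprising.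

For compound 4 the estimate is 80000 nM, with an expected range of 35000 nM to 150000 nM.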

Compound 4, half-maximal inhibitory concentration: 98200 nM
Compound 4: the middle estimate sits 1.2-fold (0.09 log units) below what was measured; the range from low to high includes it.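

In this assay, the non-aromatic cyclohexyl on the saturated chain carbon bound to a sulfur gives a second number for this position, and it stays close to the phenyl of compound 1: a 1.5-fold higher number from compound 1 to compound 4 (0.16 log units; within the scatter). The other two steps, an at least 1.0-fold lower number from compound 3 to compound 4 (0.00 log units; that floor lies within the scatter) and an at least 1.0-fold lower number from compound 2 to compound 4 (0.00 log units; that floor lies within the scatter), have floors within the scatter, so neither shows a real change at this position. Compound 2 and compound 3 remain limits, not numbers: the limit of > 100000 nM in this assay, at which 2 of the 4 values shown sit.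

Across phenyl, 4-chlorophenyl, 5-chloro-1-benzothiophen-3-yl and cyclohexyl, no step beyond the scatter has yet appeared at this position. As far as these compounds go, it remains open whether an amine or a carboxylic acid on this ring, or a longer chain between the sulfur and the ring, would produce one.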